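Methoxy to trifluoromethyl: working notes on clearance

The source may hold more compounds than are shown below. What is called first, only, known or untested is meant among the compounds shown, and "the series" means these compounds.

Measured compounds:
- compound 1 `N#Cc1cccc2c1nnn2CC1CC1`: "not determined" (no result reported) in an ADME assay on microsomes from liver (Rattus norvegicus, strain Wistar) for metabolic stability, tested at 2.5 uM; a higher number here means faster removal of the compound, a lower number slower removal
- compound 2 `COc1cccc2c1nnn2CC1CC1`: 0.8 mL/min/g
- compound 3 `FC(F)(F)c1cccc2c1nnn2CC1CC1`: not yet measured in this assay

Going by the values given here, compound 2 is the only compound with a number in this assay; in that assay compound 2 gives 0.8 mL/min/g, so there is no ordering to speak of, only this single point. Compound 1 carries a nitrile where compound 2 carries a methoxy, and for compound 1 the entry is "not determined" (no result reported), so it offers no reference for the size of any step.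

Compound 3 differs from compound 2 in one place: trifluoromethyl in place of methoxy on an aromatic carbon. Among the compounds with values here, no step between two measured compounds is available to calibrate this change. On that basis the expectation for the step from compound 2 to compound 3 in this assay is small, leaning towards slower removal, and most likely within the usual scatter: a 1.6-fold lower number from compound 2 to compound 3 (0.20 log units; within the scatter) is the estimated step. Compound 3 is accordingly expected to give about 0.5 mL/min/g, with a range from 0.2 mL/min/g to 1.3 mL/min/g.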

Compound 3, intrinsic clearance in a liver preparation (reported as CLH), per the amount of preparation that the assay uses: 0.3 mL/min/g
Beside the measured number, compound 3's estimate is 1.7-fold (0.22 log units) above it; the range from low to high includes it.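

In this assay, trifluoromethyl in place of methoxy on this aromatic carbon gives a 2.7-fold lower number from compound 2 to compound 3 (0.43 log units; beyond the scatter), a modest step but the first in the series that can be sized at all. Going by these compounds alone, the single point for compound 2 could not show whether this position responds to a change of group; this pair shows that it does, and that a number lower than that of compound 2 can be reached with the methoxy gone and no hydrogen-bond acceptor in its place. The pair gives the size and direction of the step and nothing more, and no supporting data bear on the reason for it.

Any step involving compound 1 and its nitrile cannot be read, so this one pair remains the only calibration for the position, and its generality across other groups is unknown. Also open, as far as these compounds go, is where an amine, a carboxylic acid or a single fluorine on this aromatic carbon would fall relative to compound 3, and whether the step holds when a longer chain replaces the cyclopropylmethyl group on the shared core.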